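Adding a Hydroxy Group to Compound 3: An Expected Gain

The source may hold more compounds than are shown below. What is called first, only, known or untested is meant among the compounds shown, and "the series" means these compounds.

Measured compounds:
- Compound 1, `CCCn1c(-c2ccc(O)cc2)c(C)c2ccccc21`, gives 9000 nM in a functional assay on A2780 cells (Homo sapiens) for inhibition, read by trypan blue exclusion, with a stated time of 72 h; a higher number here means a weaker inhibitor of growth, a lower number a stronger inhibitor of growth.
- Compound 2, `CCCn1c(-c2ccc(O)cc2)c(C)c2cc(O)ccc21`, gives 2300 nM in this assay.
- Compound 3, `Cc1c(-c2ccc(O)cc2)n(CCCCOc2ccccc2)c2ccccc12`, gives 3100 nM in this assay.

Compound 1 is the starting point. Two changes to it have been tested separately. The first, (hydroxy in place of hydrogen on an aromatic carbon), gives compound 2 and brings a 3.9-fold lower number from compound 1 to compound 2 (0.59 log units; beyond the scatter). The second, (phenoxymethyl in place of hydrogen on a saturated chain carbon, three bonds along the chain from an aromatic nitrogen), gives compound 3 and brings a 2.9-fold lower number from compound 1 to compound 3 (0.46 log units; beyond the scatter). Compound 2 and compound 3 lie within the scatter of each other, so nothing separates them.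

Compound 4, `Cc1c(-c2ccc(O)cc2)n(CCCCOc2ccccc2)c2ccc(O)cc12`, has not been measured. It differs from compound 3 by hydroxy in place of hydrogen on an aromatic carbon, and this is the same change that turned compound 1 into compound 2, made at the same place on the shared core; the cores of compound 3 and compound 1 differ only by phenoxymethyl in place of hydrogen on a saturated chain carbon, three bonds along the chain from an aromatic nitrogen. The change has been seen once among these compounds, on compound 1, where it was helpful beyond the scatter.

The expectation for compound 4 is therefore a step of about a 3.4-fold lower number from compound 3 to compound 4 (0.54 log units; beyond the scatter) in this assay, resting on compound 1 and compound 2, whose step was a 3.9-fold lower number from compound 1 to compound 2 (0.59 log units; beyond the scatter), applied to the value of compound 3, 3100 nM. Among the compounds with values here, the step was seen in only one pair. The same size cannot be assumed with confidence, and the range is set wide. Compound 4 is estimated at 900 nM, expected to fall between 400 nM and 2500 nM.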

Compound 4, concentration for 50% growth inhibition: 2000 nM
Compound 4: middle estimate off by 2.2-fold (0.35 log units), on the low side, and the stated range covers the measured number.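

On the core carrying the phenoxymethyl group, hydroxy in place of hydrogen brought a 1.6-fold lower number from compound 3 to compound 4 (0.19 log units; within the scatter), and on the core already carrying the hydroxy, phenoxymethyl in place of hydrogen brought a 1.2-fold lower number from compound 2 to compound 4 (0.06 log units; within the scatter), so neither step on its new core can be told from no change at all. Even so, the hydroxy change cannot be said to behave differently on the two cores, as its new step and its earlier step remain close enough to be the same step measured twice: the same change on two cores in this assay, a 3.9-fold lower number (0.59 log units; beyond the scatter) from compound 1 to compound 2 and a 1.6-fold lower number (0.19 log units; within the scatter) from compound 3 to compound 4, 2.5-fold (0.40 log units) apart, within the scatter of two such steps. The phenoxymethyl change reads the same way, so these four compounds show neither that the gain carries over in full from one core to the other nor that it is lost: the same change on two cores in this assay, a 2.9-fold lower number (0.46 log units; beyond the scatter) from compound 1 to compound 3 and a 1.2-fold lower number (0.06 log units; within the scatter) from compound 2 to compound 4, 2.5-fold (0.40 log units) apart, within the scatter of two such steps.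

Within the data shown here, with only two cores compared, it remains open whether the hydroxy change would give a clear gain on a third core, such as one with a longer chain or an amine at the end of the chain on the aromatic nitrogen. Going by these compounds, it is also open how a methoxy group or a fluorine atom on that same aromatic carbon would compare with the hydroxy group on either core.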